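A few compounds are considered here, and "the series" means these few. Any claim that something is new, unique, unknown or untested is made for them only; others in the source may bear on it.

Three compounds share one core and differ only in the aryl group on the carbonyl carbon. Compound 1 `CCCCCCCCCCCCn1nnc(C(NC(=O)c2ccc(F)cc2F)c2ccccc2)n1` carries a 2,4-difluorophenyl there and gives 490 nM in an assay on microsomes from liver for inhibition of sterol O-acyltransferase 1 (Rattus norvegicus); a lower number here means a stronger inhibitor, a higher number a weaker inhibitor. Compound 2 `CCCCCCCCCCCCn1nnc(C(NC(=O)c2ccc(OC)cc2)c2ccccc2)n1` carries a 4-methoxyphenyl and gives 600 nM in this assay. Compound 3 `CCCCCCCCCCCCn1nnc(C(NC(=O)c2ccc(C)cc2)c2ccccc2)n1` carries a 4-methylphenyl and gives 510 nM in this assay. Among these three numbers compound 3 sits second highest, though the steps to its neighbours are small: a 1.0-fold higher number from compound 1 to compound 3 (0.02 log units; within the scatter), a 1.2-fold lower number from compound 2 to compound 3 (0.07 log units; within the scatter) and a 1.2-fold higher number from compound 1 to compound 2 (0.09 log units; within the scatter), each within the scatter. Compound 4 `CCCCCCCCCCCCn1nnc(C(NC(=O)c2ccccc2[N+](=O)[O-])c2ccccc2)n1` has not been measured. It differs from compound 3 in one place: 2-nitrophenyl in place of 4-methylphenyl on a carbonyl carbon. The measured steps bear on this change in that all three exchange the aryl group on the same carbonyl carbon, and none of them moves the number beyond the scatter. Among the compounds with values here, no measured step involves a nitro group or a substituent at the 2-position alone, so the guidance is indirect. On that basis compound 4 is expected to show little change, with a 1.4-fold higher number from compound 3 to compound 4 (0.14 log units; within the scatter) as the estimated step, and a wider range than the measured steps alone would suggest. The estimate for compound 4 in this assay is 700 nM, expected to lie between 300 nM and 2000 nM.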

Compound 4, half-maximal inhibitory concentration: 240 nM
For compound 4 the middle estimate is 2.9-fold (0.46 log units) above the measured one, outside the stated range (below it).
By their numbers in this assay, from the lowest: compound 4; then compounds 1, 3 and 2 (each within the scatter of the next).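

In this assay, the aryl group on this carbonyl carbon turns out to be able to move the number beyond the scatter, with a 2.1-fold lower number from compound 3 to compound 4 (0.33 log units; beyond the scatter), a 2.5-fold lower number from compound 2 to compound 4 (0.40 log units; beyond the scatter) and a 2.0-fold lower number from compound 1 to compound 4 (0.31 log units; beyond the scatter), each a modest step. The exchanges among 2,4-difluorophenyl, 4-methoxyphenyl and 4-methylphenyl had all stayed within the scatter, so the position had looked indifferent to the aryl group, whereas 2-nitrophenyl makes compound 4 the strongest inhibitor of the four shown. Nothing available explains why this group gives the lower number.

The compounds shown do not separate the nitro group itself from the place it holds on the phenyl ring, since no other compound carries either feature alone. They also leave open how the number would respond to an amine or a carboxylic acid in place of the nitro group, and whether the step seen here would grow, hold or vanish with such a replacement.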